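A few compounds are considered here, and "the series" means these few. Any claim that something is new, unique, unknown or untested is made for them only; others in the source may bear on it.

Compound 1 `COc1ccc(OC)c(C2=NOC(COc3ccc(-c4nnnn4-c4cc(OC)c(OC)c(OC)c4)cc3N)C2)c1` gives 3500 nM in a functional assay on MDA-MB-231 cells (Homo sapiens) for cytotoxicity, read by MTT assay, with a stated time of 48 h; on this read-out higher numbers stand for weaker inhibition and lower numbers for stronger inhibition. Compound 2 `COc1cc(C2=NOC(c3cc(OC)c(OC)c(OC)c3)C2)ccc1O` gives 3600 nM in this assay. Going by the values given here, these two values lie within the scatter of each other, so they set no order, and compound 1 stands level with compound 2 on the numbers so far.

Compound 3 `COc1ccc(C2=NOC(COc3ccc(-c4nnnn4-c4cc(OC)c(OC)c(OC)c4)cc3N)C2)cc1N` is still to be measured. It keeps the core of compound 1 and changes one substituent, on a carbon with a double bond to nitrogen of the five-membered non-aromatic ring: 3-amino-4-methoxyphenyl in place of 2,5-dimethoxyphenyl (3-amino-4-methoxyphenyl in place of 2,5-dimethoxyphenyl on a carbon with a double bond to nitrogen). The entering group brings a hydrogen-bond donor that the leaving group lacks.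

Among the compounds with values here, no two measured compounds differ in one place, so the series offers no measured step to size this change. Starting from compound 1 at 3500 nM, a moderate move toward stronger inhibition is expected in this assay, though a result within the scatter would not surprise. The expected change is a 2.9-fold lower number from compound 1 to compound 3 (0.46 log units; beyond the scatter). For compound 3 the estimated value is 1200 nM, with an expected range of 200 nM to 5000 nM.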

Compound 3, half-maximal inhibitory concentration: 3000 nM
For compound 3 the middle estimate is 2.5-fold (0.40 log units) below the measured one; low and high end bracket the measured number.
By their numbers in this assay, from the lowest: compounds 3, 1 and 2 (each within the scatter of the next).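

Going by these compounds alone, this is the first measured step at this position: in this assay, 3-amino-4-methoxyphenyl in place of 2,5-dimethoxyphenyl on a carbon with a double bond to nitrogen gives a 1.2-fold lower number from compound 1 to compound 3 (0.07 log units; within the scatter), so the exchange sets no order between the two compounds. The hydrogen-bond donor that the entering group brings, and the leaving group lacks, thus comes with no change beyond the scatter in this pair, and the position accepts two differently substituted phenyl groups with the read-out held level. No supporting measurement bears on this result, so nothing can be said about why the two groups read alike.

One exchange at this position cannot show whether the position is insensitive to its substituent or whether the separate parts of the exchange offset each other; the simpler 3-aminophenyl and 4-methoxyphenyl groups would separate those parts. From the compounds shown here alone, whether the flat reading holds for groups of another kind on this carbon, such as a carboxylic acid, a trifluoromethyl-bearing phenyl or a longer alkyl chain, remains open.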